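The source may report more compounds than this note shows. Statements on the series, on what has been measured and on what is new or still open speak of the compounds shown alone.

Results so far in an ADME assay on MDCK cells (Canis lupus familiaris) for inhibition, read by LC-MS, with a stated time of 60 min, tested at 3 uM, in the presence of a further agent that is not named here; on this read-out lower numbers stand for lower permeability and higher numbers for higher permeability

Compound 1 `C[C@@H](N[C@H]1CCN(c2ccc(C(=O)NCC(=O)O)cc2)C1)c1cccc2ccccc12` gives "not determined" (no result reported)
Compound 2 `C[C@@H](N[C@H]1CCN(c2ccc(S(=O)(=O)NCCn3cnc(C(=O)O)c3C(=O)O)cc2)C1)c1cccc2ccccc12` gives "not determined" (no result reported)
Compound 3 `C[C@@H](N[C@H]1CCN(c2ccc(C(=O)NC(CO)(CO)CO)cc2)C1)c1cccc2ccccc12` gives 136 nm/s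

Within the data shown here, compound 3 at 136 nm/s holds the only number in this set, and compound 1 and compound 2 offer none to compare it with. Compound 4 `C[C@@H](N[C@H]1CCN(c2ccc(C(=O)N[C@H](CC(=O)O)C(=O)O)cc2)C1)c1cccc2ccccc12` is still to be measured in this assay and keeps the shared core. The change is 1,2-dicarboxyethyl in place of 2-hydroxy-1,1-bis(hydroxymethyl)ethyl on an amide-type nitrogen and amounts to 1,2-dicarboxyethyl in place of 2-hydroxy-1,1-bis(hydroxymethyl)ethyl on an amide-type nitrogen. Among the measured compounds shown here, no measured pair differs in one place, so the expectation rests on this structural change alone. An estimated 11-fold lower number from compound 3 to compound 4 (1.05 log units; beyond the scatter) is expected, downward and beyond the usual scatter, and a report without a number remains possible. Compound 4 is estimated at 12 nm/s with an expected range from 3 nm/s to 50 nm/s on this read-out.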

Compound 4, apparent permeability: 9 nm/s
For compound 4 the middle estimate is 1.3-fold (0.12 log units) above the measured one, within the range that was stated.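

In this assay, putting 1,2-dicarboxyethyl in place of 2-hydroxy-1,1-bis(hydroxymethyl)ethyl on the amide-type nitrogen gives a 15-fold lower number from compound 3 to compound 4 (1.18 log units; beyond the scatter) as a large step. This shows that the read-out depends strongly on the group at this position, which compound 1 and compound 2, with no numbers, could not show. Nothing available here accounts for the step. As far as these compounds go, it remains open whether a single carboxylic acid or an amine on this nitrogen would give a number nearer that of compound 3 or compound 4. From the compounds shown here alone, the outcome with a longer chain also remains open.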